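Compound 4: swapping 4-bromophenyl for 2-methylphenyl

This account rests on a few compounds, and the source may have more. Where it says the series, first, only, none or still open, it means among the compounds named here.

Measured in an ADME assay on L6 cells (Rattus norvegicus) for cytotoxicity, read by resazurin assay, with a stated time of 72 h; a higher number here means a weaker inhibitor, a lower number a stronger inhibitor:
compound 1 `Cc1ccc(C(O)(c2ccc(Cl)cc2)c2cccnc2)cc1`: 61000 nM
compound 2 `OC(c1ccc(Cl)cc1)(c1cccnc1)c1ccccc1F`: > 100000 nM (a limit of the assay, not a number)
compound 3 `OC(c1ccc(Cl)cc1)(c1ccc(Br)cc1)c1cccnc1`: 57000 nM

Compound 3 stands level with compound 1 (a 1.1-fold lower number from compound 1 to compound 3 (0.03 log units; within the scatter)). Compound 2 offers only its limit for comparison.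

Compound 4 `Cc1ccccc1C(O)(c1ccc(Cl)cc1)c1cccnc1` differs from compound 3 as follows: 2-methylphenyl in place of 4-bromophenyl on a saturated chain carbon bound to two aromatic carbons and an oxygen on a saturated carbon (2-methylphenyl in place of 4-bromophenyl).

Among the measured compounds shown here, three measured steps bear on this. Bromo in place of methyl gave the step already cited, which suggests little from that exchange alone. The 2-fluorophenyl group of compound 2 is the closest match to the entering group, and it gives only floors (an at least 1.6-fold higher number from compound 1 to compound 2 (0.21 log units; that floor lies within the scatter) and an at least 1.7-fold lower number from compound 2 to compound 3 (0.24 log units; that floor lies within the scatter)). A slight rise in this assay is therefore the likelier direction, but no step beyond the scatter is expected. The expected step is small (a 1.3-fold higher number from compound 3 to compound 4 (0.12 log units; within the scatter)). A reading at the limit remains possible.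

For compound 4 the estimate is 75000 nM (expected range 35000 nM to 130000 nM).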

Compound 4, half-maximal inhibitory concentration: 82000 nM
Estimate against measurement, compound 4: 1.1-fold (0.04 log units) below, within the range that was stated.
By their numbers in this assay, from the lowest: compounds 3, 1 and 4 (each within the scatter of the next). At a limit, above all of these: compound 2.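

In this assay, 2-methylphenyl on this saturated chain carbon cannot be told apart from either 4-bromophenyl or 4-methylphenyl: a 1.4-fold higher number from compound 3 to compound 4 (0.16 log units; within the scatter) and a 1.3-fold higher number from compound 1 to compound 4 (0.13 log units; within the scatter), both within the scatter. Compounds 1, 3 and 4 therefore show that this exchange, including the shift from 4-methylphenyl to 2-methylphenyl, leaves the reading unchanged within the scatter. Methyl in place of fluoro gives only a floor, an at least 1.2-fold lower number from compound 2 to compound 4 (0.08 log units; that floor lies within the scatter), and the start of that step is a limit, not a number: the limit of > 100000 nM in this assay, at which 1 of the 4 values shown sits.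

From the compounds shown here alone, the size of any difference between 2-fluorophenyl and 2-methylphenyl stays open, as does whether any exchange at this place can produce a step beyond the scatter. An amine or a carboxylic acid on this ring would test that, as would a longer chain in place of the methyl of 2-methylphenyl.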